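Cytotoxicity notes on the anilino-imidazole series

This account rests on a few compounds, and the source may have more. Where it says the series, first, only, none or still open, it means among the compounds named here.

Measured so far:
compound 1 `COC(=O)c1ccc(NCc2cncn2Cc2ccc(C)cc2)cc1-c1ccccc1` — 50000 nM
compound 2 `c1ccc(-c2ccc(Cn3cncc3CNc3ccccc3-c3ccccc3)cc2)cc1` — > 10000 nM

Among the compounds with values here, in a toxicity assay on NIH3T3 cells (Mus musculus) for cytotoxicity, read by resazurin assay (a lower number here means that less compound is needed, a higher number that more compound is needed for the effect), compound 1 gives 50000 nM, the only plain number in the set. For compound 2 the assay reports only a limit, > 10000 nM, not a number. So compound 1 stands alone as a quantified value, and the picture is framed by the limit of > 10000 nM in this assay, at which 1 of the 2 values shown sits. Both entries point the same way: neither compound shows cytotoxicity at the lower end of the tested range.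

Compound 3 `COC(=O)c1ccc(NCc2cncn2Cc2ccc(-c3ccccc3)cc2)cc1-c1ccccc1` differs from compound 1 in one place: phenyl in place of methyl on an aromatic carbon. Within the data shown here, no pair of measured compounds separates this change on its own, so its size cannot be read from the data. Compound 2 carries the same 4-phenylphenyl unit as compound 3 and sits at a limit, which gives no sign that this unit brings cytotoxicity into the measurable range. The step from compound 1 to compound 3 in this assay is therefore expected to stay within the usual scatter, with no direction beyond it, a 1.3-fold lower number from compound 1 to compound 3 (0.10 log units; within the scatter). Compound 3 is estimated at 40000 nM, in the range 12000 nM to 120000 nM.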

Compound 3, half-maximal effective concentration: > 1000 nM
Compound 3 gave a limit, no number (the forecaster's own chance of this, stated with the estimate: 40%); the middle value does not contradict the limit.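

In this assay, within the data shown here, compound 3 gives > 1000 nM, which is a limit and not a number, so no step from compound 1 to compound 3 can be read. The compounds shown leave open whether phenyl in place of methyl on an aromatic carbon shifts the number in this assay at all, and in which direction.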